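A few compounds are considered here, and "the series" means these few. Any claim that something is new, unique, unknown or untested is made for them only; others in the source may bear on it.

Measured so far:
- compound 1 `COc1ccc(/C=C2\C(=O)N(c3c(Cl)cccc3Cl)c3ccccc32)cc1OC`: in a functional assay on HuTu80 cells (Homo sapiens) for cytotoxicity, read by MTT assay, with a stated time of 72 h (on this read-out lower numbers stand for an effect already at smaller amounts and higher numbers for an effect only at larger amounts of compound), compound 1 gives < 1 ug/mL, which is a limit of the assay and not a number.
- compound 2 `CN(C)c1ccc(/C=C2\C(=O)N(c3c(Cl)cccc3Cl)c3ccccc32)cc1`: in this assay compound 2 gives < 1 ug/mL, again a limit of the assay rather than a number.

Within the data shown here, compound 2 therefore stands at the bottom edge of what this assay reports; as the limit of < 1 ug/mL in this assay, at which 2 of the 2 values shown sit, shows, every value so far sits at that same limit, so no spread among the measured compounds is visible and no step between them can be given a size.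

Compound 3 `O=C1/C(=C\c2ccccc2Cl)c2ccccc2N1c1c(Cl)cccc1Cl` is not yet measured. It differs from compound 2 in one place: 2-chlorophenyl in place of 4-(dimethylamino)phenyl on a double-bonded chain carbon bound to a double-bonded ring carbon. The shared core is kept unchanged.

Among the measured compounds shown here, with no measured step to lean on, the expectation for compound 3 rests only on the fact that both measured compounds reach the limit. The step that the limit leaves unreadable from compound 2 to compound 3 is expected to be small and not beyond the scatter. For compound 3 the estimated value in this assay is 0.8 ug/mL, with a range from 0.2 ug/mL to 3 ug/mL, and a fair chance that again only a limit is reported.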

Compound 3, concentration for half-maximal effect: > 100 ug/mL
Compound 3 gave a limit, no number; the forecaster's own chance of this, stated with the estimate: 50%; middle value at least 120-fold (2.09 log units) from the limit.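

Working notes on the series: in this assay, 2-chlorophenyl in place of 4-(dimethylamino)phenyl on a double-bonded chain carbon bound to a double-bonded ring carbon, with the shared core kept unchanged, gives an at least 100-fold higher number from compound 2 to compound 3 (2.00 log units; beyond the scatter). Up to this point the series showed no spread at all, and compound 2 stands at a limit of the assay, not at a number: the limit of < 1 ug/mL in this assay, at which 2 of the 3 values shown sit. Compound 3 is also a limit and not a number, now at the opposite edge of the assay, so this position clearly does not tolerate every aromatic group, while the full size of the step remains unread: the limit of > 100 ug/mL in this assay, at which 1 of the 3 values shown sits.

The compounds shown do not separate the departure of the dimethylamino group from the arrival of the chlorine, and a plain phenyl at this place would be the direct link between the two. Any step between compounds held at the same limit cannot be read, and no cause for the large step can be taken from these values.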